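This account rests on a few compounds, and the source may have more. Where it says the series, first, only, none or still open, it means among the compounds named here.

The measured compounds:
compound 1 `CCCCCOC1=C(C(=O)c2ccccc2)C(c2ccc(Br)cc2)N(CCCn2ccnc2)C1=O` gives 7290 nM in a functional assay on A549 cells (Homo sapiens) for antiproliferative activity, read by MTT assay, with a stated time of 72 h; on this read-out lower numbers stand for stronger inhibition and higher numbers for weaker inhibition;
compound 2 `Cc1ccc(NC2=C(C(=O)c3ccccc3)C(c3ccc(Br)cc3)N(CCCn3ccnc3)C2=O)cc1` gives 29400 nM;
compound 3 `O=C(C1=C(Nc2ccc(F)cc2)C(=O)N(CCCn2ccnc2)C1c1ccc(Br)cc1)c1ccccc1` gives 27400 nM.

Among these three numbers compound 2 stands highest, the weakest inhibition shown, though compound 3 is not separated from it: the step of a 1.1-fold lower number from compound 2 to compound 3 (0.03 log units; within the scatter) lies within the scatter. Both anilino compounds sit well apart from the pentyloxy compound, as the steps of a 4.0-fold higher number from compound 1 to compound 2 (0.61 log units; beyond the scatter) and a 3.8-fold higher number from compound 1 to compound 3 (0.58 log units; beyond the scatter) show.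

Compound 4 `O=C(C1=C(Nc2ccccc2Br)C(=O)N(CCCn2ccnc2)C1c1ccc(Br)cc1)c1ccccc1` differs from compound 2 by 2-bromophenyl in place of 4-methylphenyl on an amine nitrogen. Among the measured compounds shown here, only one measured step bears directly on this change, the exchange of the substituent on the anilino aromatic ring between compound 2 and compound 3, and that step stayed within the scatter. For the measured compounds named here, no measured pair tests a bromine on that ring or a substituent at the position it now occupies, so the comparison rests on a single uninformative step. The expectation is therefore no step beyond the scatter in this assay, that is a 1.1-fold lower number from compound 2 to compound 4 (0.04 log units; within the scatter). Compound 4 is estimated at 27000 nM, with a range from 11000 nM to 65000 nM, the breadth of the range reflecting how little the measured steps say about this particular change.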

Compound 4, half-maximal inhibitory concentration: 20100 nM
Compound 4: middle estimate off by 1.3-fold (0.13 log units), on the high side, within the range that was stated.
By their numbers in this assay, from the lowest: compound 1; then compounds 4, 3 and 2 (each within the scatter of the next).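

In this assay, 2-bromophenyl on the amine nitrogen stays within the scatter of both earlier anilino compounds, with a 1.5-fold lower number from compound 2 to compound 4 (0.17 log units; within the scatter) and a 1.4-fold lower number from compound 3 to compound 4 (0.13 log units; within the scatter), so a third aromatic group at this place, now carrying bromine, again produces no separable change. The separation from the pentyloxy compound also holds for this third anilino compound, at a 2.8-fold higher number from compound 1 to compound 4 (0.44 log units; beyond the scatter), which is beyond the scatter and makes compounds 2, 3 and 4 alike in giving higher numbers than compound 1. Nothing measured here accounts for either observation.

As far as these compounds go, what remains open is whether the separation from compound 1 follows the atom attached to the double-bonded ring carbon or the aromatic ring itself, a question that a pentylamino or a phenoxy group at that carbon would help to divide. From the compounds shown here alone, it also remains open whether the anilino ring stays this unresponsive with a group of a different kind, such as a carboxylic acid or a dimethylamino group, in place of the methyl, fluoro and bromo substituents seen so far.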